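Acyl thiourea series: benzothiophene for furan at the carbonyl

The source may hold more compounds than are shown below. What is called first, only, known or untested is meant among the compounds shown, and "the series" means these compounds.

Compound 2 `O=C(NC(=S)N1CCc2c(OCCCCCOc3ccc(Cl)cc3)cccc21)c1ccoc1` and compound 1 `N#Cc1ccc(C(=O)NC(=S)N2CCc3c(OCCCCCOc4ccc(Cl)cc4)cccc32)cc1` share one core and differ only in the group on the carbonyl carbon. Among the measured compounds shown here, in an ADME assay on Huh-7 cells (Homo sapiens) for cytotoxicity (a higher number here means that more compound is tolerated, a lower number that less compound is tolerated), compound 2 gives 20100 nM, the only number in hand for the series. Compound 1 gives > 50000 nM in this assay, which is a limit and not a number. For the measured compounds named here, the single measured step, an at least 2.4-fold lower number from compound 1 to compound 2 (0.39 log units; beyond the scatter), is bounded only on one side because of the limit of > 50000 nM in this assay, at which 1 of the 2 values shown sits, so its true size is open.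

Compound 3 `O=C(NC(=S)N1CCc2c(OCCCCCOc3ccc(Cl)cc3)cccc21)c1cc2ccccc2s1` carries 1-benzothiophen-2-yl in place of furan-3-yl on a carbonyl carbon. Going by the values given here, no measured step covers a 1-benzothiophen-2-yl at this carbonyl; the one step in hand runs between 4-cyanophenyl and furan-3-yl, neither of which is the entering group, so it gives only a rough sense of how much this position can move the read-out. With that sole step at least modest, a change of similar or smaller size in either direction is plausible. Compound 3 is expected to give about 12000 nM in this assay, within 3500 nM to 45000 nM. The expected step is a 1.7-fold lower number from compound 2 to compound 3 (0.22 log units; within the scatter), within the usual scatter.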

Compound 3, half-maximal cytotoxic concentration: > 50000 nM
Compound 3: a limit, no number (the forecaster's own chance of this, stated with the estimate: 15%); at least 4.1-fold (0.61 log units) between middle value and limit.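

In this assay, the group on the carbonyl carbon is now seen to move the read-out in both directions around furan-3-yl's value, since 1-benzothiophen-2-yl in place of furan-3-yl gives an at least 2.4-fold higher number from compound 2 to compound 3 (0.39 log units; beyond the scatter). Read with an at least 2.4-fold lower number from compound 1 to compound 2 (0.39 log units; beyond the scatter), this leaves furan-3-yl as the only one of the three groups shown that yields a number, while two different groups, 4-cyanophenyl and 1-benzothiophen-2-yl, each give a limit instead. Compound 3 gives > 50000 nM, which is a limit and not a number.

The step between compound 1 and compound 3 cannot be read, and how far the number rises on leaving furan-3-yl remains unknown: the limit of > 50000 nM in this assay, at which 2 of the 3 values shown sit.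

Also open, going by these compounds, is whether an amine or a carboxylic acid carried on the group at this carbonyl carbon, or a plain alkyl chain in place of the ring, would bring the number back down or leave it at the limit.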